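The source may report more compounds than this note shows. Statements on the series, on what has been measured and on what is new or still open speak of the compounds shown alone.

Measured compounds:
Compound 1 `Cc1oc(-c2ccc(Cl)c(Cl)c2)nc1CN1CCC(C(=O)NCCCN2C[C@H](C)C[C@H](C)C2)CC1` gives 522 10^-6 cm/s in a physicochemical assay for permeability, using PAMPA; on this read-out lower numbers stand for lower permeability and higher numbers for higher permeability.
Compound 2 `Cc1oc(-c2c(Cl)cccc2C(F)(F)F)nc1CN1CCC(C(=O)NCCCN2C[C@H](C)C[C@H](C)C2)CC1` gives "not determined" (no result reported) in this assay.

For the measured compounds named here, compound 2 stands without a number; compound 1 carries the only value. Compound 3 `Cc1ccc(-c2nc(CN3CCC(C(=O)NCCCN4C[C@H](C)C[C@H](C)C4)CC3)c(C)o2)cc1C` differs from compound 2 by 3,4-dimethylphenyl in place of 2-chloro-6-(trifluoromethyl)phenyl on an aromatic carbon. Going by the values given here, no measured step exists around compound 2, so the size and direction of the change in this assay cannot be read from a neighbouring pair; a shift beyond the usual scatter is not expected in either direction. Because compound 1 gives 522 10^-6 cm/s, a value of the same order is expected for compound 3. Compound 3 is estimated at 500 10^-6 cm/s in this assay, range 250 10^-6 cm/s to 1000 10^-6 cm/s.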

Compound 3, apparent permeability: 219 10^-6 cm/s
Compound 3: middle estimate off by 2.3-fold (0.36 log units), on the high side; the measured number lies below the stated range.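

In this assay, 3,4-dimethylphenyl in place of 3,4-dichlorophenyl on the aromatic carbon gives a 2.4-fold lower number from compound 1 to compound 3 (0.38 log units; beyond the scatter), a modest step beyond the usual scatter. For the compounds shown here, this is the first readable step, and it shows that the read-out at this position moves with the substituents on the phenyl ring. No available evidence bears on the reason for this step.

Steps involving compound 2 cannot be read, so the effect of 2-chloro-6-(trifluoromethyl)phenyl remains open. Also open, from the compounds shown here alone, is how a phenyl ring carrying a methoxy group, a nitrile or an amine would compare with compound 1 and compound 3.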